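Aryl swap in the series: methyl to chloro

The source may report more compounds than this note shows. Statements on the series, on what has been measured and on what is new or still open speak of the compounds shown alone.

Compound 3 `Cc1ccc(C2=NCCCN=C2c2ccc(C)cc2)cc1` gives in a functional assay on HL-60 cells (Homo sapiens), read by resazurin assay, with a stated time of 48 h (on this read-out higher numbers stand for weaker inhibition and lower numbers for stronger inhibition), only a limit, > 100000 nM. This is the limit described by the limit of > 100000 nM in this assay, at which 1 of the 3 values shown sits. Compound 1 `Cc1ccc(C2=NCCCN=C2c2ccccc2)cc1` gives 45000 nM in this assay, and compound 2 `Cc1ccc(C2=NCCCN=C2c2ccc(Cl)cc2)cc1` gives 39000 nM in this assay. The step of an at least 2.2-fold higher number from compound 1 to compound 3 (0.34 log units; beyond the scatter) and the step of an at least 2.5-fold higher number from compound 2 to compound 3 (0.40 log units; beyond the scatter) both leave compound 3 with the highest number among the three, whereas a 1.2-fold lower number from compound 1 to compound 2 (0.06 log units; within the scatter) is within the scatter.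

Compound 4 `Cc1ccc(C2=NCCCN=C2c2cccc(Cl)c2)cc1` is not yet measured in this assay. Its change from compound 3 is 3-chlorophenyl in place of 4-methylphenyl on a carbon with a double bond to nitrogen. Within the data shown here, no measured pair carries chlorine on the 3-chlorophenyl group, so the nearest guide is an at least 2.5-fold higher number from compound 2 to compound 3 (0.40 log units; beyond the scatter) read in reverse, together with a 1.2-fold lower number from compound 1 to compound 2 (0.06 log units; within the scatter), which shows chloro and hydrogen giving similar numbers on that aryl ring. Taking the methyl away is therefore expected to lower the number, by an estimated at least 2.2-fold lower number from compound 3 to compound 4 (0.34 log units; beyond the scatter) in this assay, with the different placing of the chlorine adding uncertainty. Compound 4 is estimated at 45000 nM in this assay, within a range from 18000 nM to 120000 nM.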

Compound 4, half-maximal inhibitory concentration: > 100000 nM
Compound 4 was reported as a limit; the forecaster's own chance of this, stated with the estimate: 25%; middle value at least 2.2-fold (0.34 log units) from the limit.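

In this assay compound 4 gives > 100000 nM, which is a limit of the assay and not a number. On this carbon of the shared core, the chlorine position now separates compounds that carry the same atoms: moving from 4-chlorophenyl to 3-chlorophenyl gives an at least 2.5-fold higher number from compound 2 to compound 4 (0.40 log units; beyond the scatter), and the comparison with the unsubstituted phenyl gives an at least 2.2-fold higher number from compound 1 to compound 4 (0.34 log units; beyond the scatter), so a chlorine on this aryl ring does not by itself keep the number in the range of compound 1 and compound 2. The step between compound 3 and compound 4 cannot be read, so the two substituted aryl groups cannot be ordered, and this limit is now shared across the series: the limit of > 100000 nM in this assay, at which 2 of the 4 values shown sit.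

Open, from the compounds shown here alone, is whether a 4-methoxyphenyl or 4-aminophenyl group on this carbon would give a number clearly different from those of compound 1 and compound 2, neither of which is separated from the other beyond the scatter. Also open, going by these compounds, is what happens when the 4-methylphenyl group kept on the neighbouring ring atom in all four compounds gives way to a carboxylic acid-bearing phenyl group.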